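A few compounds are considered here, and "the series" means these few. Any claim that something is new, unique, unknown or untested is made for them only; others in the source may bear on it.

Measured so far:
- compound 1 `C=CC1=C(C(=O)NCc2ccc(C)cc2)C(c2ccc(F)cc2)OC1`: > 100000 nM
- compound 2 `C=CC1=C(C(=O)NCCC)C(c2ccc(Cl)c(Cl)c2)OC1`: > 100000 nM
- compound 3 `C=CC1=C(C(=O)NC(C)(C)C)C(c2ccc(OC)cc2)OC1`: > 100000 nM

All three compounds were tested in a functional assay on A549 cells (Homo sapiens) for cytotoxicity, read by MTT assay, with a stated time of 24 h; a lower number here means a stronger inhibitor, a higher number a weaker inhibitor. The value given for compound 1 is not a number but a limit of the assay, and compound 1 therefore stands at the limit of > 100000 nM in this assay, at which 3 of the 3 values shown sit. For the measured compounds named here, the values of compound 2 and compound 3 are likewise limits, so no compound on this list can be placed above or below another on what has been measured.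

Compound 4 `C=CC1=C(C(=O)NCC(C)C)C(c2ccc(F)cc2)OC1` is the untested compound. It differs from compound 1 in one place: isopropyl in place of 4-methylphenyl on a saturated chain carbon bound to an amide-type nitrogen. Going by the values given here, no step between two measured compounds has been recorded here, so the size of this change on the read-out rests only on what the three limits show. Since compound 1 sits at the limit > 100000 nM, and the compounds around it share that limit, the step is expected to be a step that the limit leaves unreadable from compound 1 to compound 4, with no shift beyond the scatter. Compound 4 is therefore estimated at 150000 nM, in a range from 60000 nM to 400000 nM, and most likely the assay will again report only a limit.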

Compound 4, half-maximal inhibitory concentration: > 100000 nM
Compound 4 gave a limit, no number (the forecaster's own chance of this, stated with the estimate: 85%); the middle value lies beyond the limit too.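

Compound 1 and compound 4 each give only a limit, not a number, in this assay so no step can be read for the change from 4-methylbenzyl to isobutyl: the limit of > 100000 nM in this assay, at which 4 of the 4 values shown sit.

The compounds shown leave open how far beyond that limit each one lies, and whether they differ from one another at all in this assay.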